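Homologation of the acyl hydrazide in a fused-ring series

This account rests on a few compounds, and the source may have more. Where it says the series, first, only, none or still open, it means among the compounds named here.

Measured compounds:
compound 1 `COc1ccc(-c2cnc3scc(C(=O)NNC(C)=O)n23)cc1`: 17900 nM
compound 2 `CCC(=O)NNC(=O)c1csc2ncc(-c3ccc(OC)cc3)n12`: 56200 nM
compound 3 `CCC(=O)NNC(=O)c1csc2ncc(-c3ccc(Br)cc3)n12`: 23100 nM

All three were tested in a functional assay on HeLa cells (Homo sapiens) for antiproliferative activity, read by MTT assay, with a stated time of 72 h; a higher number here means a weaker inhibitor, a lower number a stronger inhibitor. Compound 1 and compound 2 share a core and differ only by methyl in place of hydrogen on a saturated chain carbon bound to a carbonyl carbon; that change gave a 3.1-fold higher number from compound 1 to compound 2 (0.50 log units; beyond the scatter). Compound 2 and compound 3 differ by a bromo in place of the methoxy on the aromatic carbon, which gave a 2.4-fold lower number from compound 2 to compound 3 (0.39 log units; beyond the scatter). The difference between the core of compound 1 and that of compound 3 is not broken down here; compound 3 stands close to compound 1, within the usual scatter.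

Compound 4 `CCCC(=O)NNC(=O)c1csc2ncc(-c3ccc(Br)cc3)n12` is not yet measured. It differs from compound 3 by methyl in place of hydrogen on a saturated chain carbon, two bonds along the chain from a carbonyl carbon. This is the same kind of change as the step from compound 1 to compound 2, but not the same: there the entering methyl sits on a saturated chain carbon bound to a carbonyl carbon, whereas here it sits on a saturated chain carbon, two bonds along the chain from a carbonyl carbon. Among the compounds with values here, only one such step is known in this set, so the expectation rests on a single precedent.

For compound 4 in this assay the step is expected to resemble the earlier one, an estimated 1.9-fold higher number from compound 3 to compound 4 (0.29 log units; within the scatter), because compound 2 gave a 3.1-fold higher number from compound 1 to compound 2 (0.50 log units; beyond the scatter) on the same kind of lengthening. The expected value for compound 4 is 45000 nM, with a likely range from 18000 nM to 110000 nM.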

Compound 4, half-maximal inhibitory concentration: 31900 nM
The estimate for compound 4 lay 1.4-fold (0.15 log units) above the measured number, and the stated range covers the measured number.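

In this assay, going from propanoyl to propylcarbonyl on the bromo-substituted core gives a 1.4-fold higher number from compound 3 to compound 4 (0.14 log units; within the scatter), so this lengthening has no effect on this core that can be told from scatter. Set beside the earlier lengthening on the methoxy-substituted core, the two steps cannot be told apart, and these data give no ground for saying the change behaves differently on the two cores: the same change on two cores in this assay, a 3.1-fold higher number (0.50 log units; beyond the scatter) from compound 1 to compound 2 and a 1.4-fold higher number (0.14 log units; within the scatter) from compound 3 to compound 4, 2.3-fold (0.36 log units) apart, within the scatter of two such steps. Within the data shown here, that agreement does not show that the change carries over unchanged, as each core offers a single step, the entering methyl sits at a different place along the chain in each, and only the step on the methoxy-substituted core lies beyond the scatter.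

The compounds shown leave open whether the acetyl group on the bromo-substituted core and the propylcarbonyl group on the methoxy-substituted core would complete the same picture, with both substituents then compared at each chain length. Also open, going by these compounds, is how a longer chain, a branched isopropyl group, or a chain ending in an amine or a carboxylic acid would read in this assay.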